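A few compounds are considered here, and "the series" means these few. Any claim that something is new, unique, unknown or untested is made for them only; others in the source may bear on it.

Compound 1 `Nc1nc(NCc2ccccc2)c2ncn(/C=C3/CC3(CO)CO)c2n1` gives in an ADME assay on HFF cells (Homo sapiens) for cytotoxicity, with a stated time of 8 days; a higher number here means that more compound is tolerated, a lower number that less compound is tolerated > 300000 nM, which is a limit of the assay rather than a measured number.
Compound 2 `CCCCNc1nc(N)nc2c1ncn2/C=C1/CC1(CO)CO` gives in this assay > 300000 nM, again a limit of the assay.
Compound 3 `COCCOc1nc(N)nc2c1ncn2/C=C1/CC1(CO)CO` gives in this assay > 300000 nM, also a limit of the assay.

Compound 2 therefore stands nowhere in particular on these numbers: only a limit is known for it, and the two other values shown are limits as well. All three compounds sit at the limit of > 300000 nM in this assay, at which 3 of the 3 values shown sit, so none of the cells in this study was harmed at the highest concentration tested.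

The new compound, compound 4 `Nc1nc(SCc2ccccc2)c2ncn(/C=C3/CC3(CO)CO)c2n1`, differs from compound 2 in one place: benzylsulfanyl in place of butylamino on an aromatic carbon. The measured steps that bear on such a swap at that aromatic carbon are a step that the two limits leave unreadable from compound 2 to compound 3, a step that the two limits leave unreadable from compound 1 to compound 2 and a step that the two limits leave unreadable from compound 1 to compound 3; each of them is unreadable, since both ends sit at the limit. No step in this assay has yet shown a readable size in either direction, so there is nothing here to suggest a move beyond the scatter.

Compound 4 is thus expected to give 300000 nM, with a range from 100000 nM to 1000000 nM, most probably reported once more as a limit. That corresponds to an estimated a number no higher from compound 2 to compound 4 (the limit leaves the size open).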

Compound 4, half-maximal cytotoxic concentration: > 300000 nM
Compound 4: a limit, no number; the forecaster's own chance of this, stated with the estimate: 85%; the middle value sits exactly at the limit.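

Compound 4 gives a limit of the assay rather than a number, so none of the steps to it from compound 1, compound 2 or compound 3 can be read. All four compounds share one reading: the limit of > 300000 nM in this assay, at which 4 of the 4 values shown sit. The compounds shown leave open what concentration of any of them would harm the cells in this assay.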